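Replacing a dimethylamino chain with a cyanopyrrole chain

A few compounds are considered here, and "the series" means these few. Any claim that something is new, unique, unknown or untested is made for them only; others in the source may bear on it.

Among the compounds with values here, compound 2 `COc1ccc2c(c1)[n+]([O-])c(NCCN(C)C)n[n+]2[O-]` gives the only number in a physicochemical assay for solubility, in the presence of a further agent that is not named here (a lower number here means a less soluble compound, a higher number a more soluble compound), where compound 2 reaches 46000000 nM. Compound 1 `CCc1ccc2c(c1)[n+]([O-])c(NCCN(C)C)n[n+]2[O-]` instead sits at a limit of the assay, > 49000000 nM, which is a limit and not a number; this is the limit of > 49000000 nM in this assay, at which 1 of the 2 values shown sits. Within the data shown here, the single measured step, an at least 1.0-fold lower number from compound 1 to compound 2 (0.02 log units; that floor lies within the scatter), concerns a group on an aromatic carbon. Among the measured compounds shown here, compound 3 `COc1ccc2c(c1)[n+]([O-])c(NCCCn1ccc(C#N)c1)n[n+]2[O-]` differs from compound 2 elsewhere, by (3-cyano-1H-pyrrol-1-yl)methyl in place of dimethylamino on a saturated chain carbon, two bonds along the chain from a nitrogen on an aromatic ring, so no measured step bears on it. Compound 3 is nonetheless expected to shift by a 9.2-fold lower number from compound 2 to compound 3 (0.96 log units; beyond the scatter) in this assay, an estimate of 5000000 nM with a range from 500000 nM to 40000000 nM.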

Compound 3, solubility: 47000000 nM
Estimate against measurement, compound 3: 9.4-fold (0.97 log units) below, outside the stated range (above it).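

In this assay the swap at this saturated chain carbon gives no difference that can be told from the scatter (a 1.0-fold higher number from compound 2 to compound 3 (0.01 log units; within the scatter)), so (3-cyano-1H-pyrrol-1-yl)methyl can stand in place of dimethylamino with the reading held. The earlier compounds shown here differed only on an aromatic carbon and showed nothing about this chain position. Compound 1 remains a limit and not a number: the limit of > 49000000 nM in this assay, at which 1 of the 3 values shown sits.

From the compounds shown here alone, whether a primary amine, a carboxylic acid or a longer chain here would hold the reading stays open. So does whether the pyrrole ring or the nitrile matters on its own.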